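This account rests on a few compounds, and the source may have more. Where it says the series, first, only, none or still open, it means among the compounds named here.

In an ADME assay on HCT-116 cells (Homo sapiens) for antiproliferative activity (on this read-out lower numbers stand for stronger inhibition and higher numbers for weaker inhibition), compound 1 (`COc1ccc(C(C)=O)cc1COc1cccc(C)c1`) gives 24000 nM and compound 2 (`COc1ccc(C(N)=O)cc1/C=C/c1ccc(C)cc1`) gives 48000 nM on the same scale. Compound 3 (`COc1ccc(C(N)=O)cc1/C=C/c1ccccc1F`) gives 26000 nM and lies within the scatter of both other compounds, so these numbers set no order among them.

Compound 4 (`COc1ccc(C(N)=O)cc1/C=C/c1ccccc1Cl`) has chloro in place of fluoro on an aromatic carbon, ortho to a large group (chloro in place of fluoro on an aromatic carbon). Going by the values given here, no measured pair differs in one place only, so the data do not show directly what such a swap does.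

Among the compounds with values here, the only guide is that compound 2 at 48000 nM and compound 3 at 26000 nM carry different substituents on the shared core and still stay within the scatter of each other. In this assay a step no larger than the scatter is therefore expected, with no clear direction. The expected change is a 1.1-fold lower number from compound 3 to compound 4 (0.03 log units; within the scatter) and stays inside the scatter. Compound 4 is estimated at 24000 nM with an expected range from 11000 nM to 50000 nM in this read-out.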

Compound 4, half-maximal inhibitory concentration: > 50000 nM
Compound 4 ended at the assay's limit; the forecaster's own chance of this, stated with the estimate: 10%; middle value at least 2.0-fold (0.31 log units) away from the limit.
By their numbers in this assay, from the lowest: compounds 1, 3 and 2 (each within the scatter of the next). At a limit, above all of these: compound 4.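

Chloro in place of fluoro on an aromatic carbon, ortho to a large group, gives the first step in the series that changes one place only: an at least 1.9-fold higher number from compound 3 to compound 4 (0.28 log units; that floor lies within the scatter). In this assay, compound 4 stands at a limit and not at a number: the limit of > 50000 nM in this assay, at which 1 of the 4 values shown sits. At this position, compound 3 with fluoro gives a value inside the range of the read-out and compound 4 with chloro does not, but the floor of the step stays within the scatter, so its true size cannot be read.

As far as these compounds go, how far compound 4 lies past the limit remains open. Also open, from the compounds shown here alone, is whether an amine or a carboxylic acid on this aromatic carbon would give a value inside the range of the read-out.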